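Swapping isopropyl for benzyl on a weak inhibitor

The source may report more compounds than this note shows. Statements on the series, on what has been measured and on what is new or still open speak of the compounds shown alone.

- Compound 1 `CCCCc1ccc(-c2c(CC)[nH]c(=O)n2C)cc1`: 13900 nM
- Compound 2 `CCCCOc1ccc(-c2c(C)[nH]c(=O)n2C)cc1`: 5100 nM
- Compound 3 `CCCCc1ccc(-c2c(C)[nH]c(=O)n2C(C)C)cc1`: 10700 nM

In a functional assay on brain (Rattus norvegicus, strain Wistar) for inhibition (a higher number here means a weaker inhibitor, a lower number a stronger inhibitor), compound 3 gives 10700 nM. That places it within the usual scatter of compound 1, while compound 2 has a lower number beyond the scatter, marking it as the stronger inhibitor of that pair.

Compound 4 `CCCCc1ccc(-c2c(C)[nH]c(=O)n2Cc2ccccc2)cc1` carries benzyl in place of isopropyl on an aromatic nitrogen. Among the measured compounds shown here, no two measured compounds differ in only one place, so the data offer no direct guide to this change. In this assay, no step beyond the scatter is expected. The estimated step is a 1.3-fold lower number from compound 3 to compound 4 (0.13 log units; within the scatter), a small one toward a lower number. For compound 4 the expected value is 8000 nM, with an estimated range of 2500 nM to 22000 nM.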

Compound 4, half-maximal inhibitory concentration: 12400 nM
Compound 4: the middle estimate sits 1.6-fold (0.19 log units) below what was measured; low and high end bracket the measured number.
By their numbers in this assay, from the lowest: compound 2; then compounds 3, 4 and 1 (each within the scatter of the next).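

On an aromatic nitrogen, benzyl in place of isopropyl adds a six-membered aromatic ring, yet this assay records a 1.2-fold higher number from compound 3 to compound 4 (0.06 log units; within the scatter) and so no real shift. This position therefore tolerates the larger benzyl group with no measurable gain or loss in inhibition, at least on this shared core. Nothing available explains this result.

Going by these compounds, whether this nitrogen is equally indifferent to other kinds of group remains open. A benzyl ring carrying an amine, or a carboxylic acid on a longer chain at this position, might move the number beyond the scatter.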